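Trimming the Ether Side Chain on a Chlorinated Acid Core

A few compounds are considered here, and "the series" means these few. Any claim that something is new, unique, unknown or untested is made for them only; others in the source may bear on it.

Measured compounds:
compound 1, `O=C(O)CCn1c(=O)oc2cc(OCC3CCC3)c(Cl)cc21`: 2.9
compound 2, `C[C@@H](Oc1cc2sc(=O)n(CCC(=O)O)c2cc1Cl)c1ccccn1`: 1.81
compound 3, `C[C@@H](Oc1cc2onc(CCC(=O)O)c2cc1Cl)c1ccc(F)cn1`: 2.47

Of the compounds shown here, three have been read in a physicochemical assay for lipophilicity, read by HPLC, at pH 7.4; on this read-out higher numbers stand for higher lipophilicity and lower numbers for lower lipophilicity. Among them compound 1 stands highest; compound 3 lies nearest to it, and compound 2 furthest, both gaps falling beyond the usual scatter. Among the measured compounds shown here, none of the three pairs differs in a single place, so no clean step between measured compounds is available.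

Compound 4, `CCOc1cc2oc(=O)n(CCC(=O)O)c2cc1Cl`, keeps the core of compound 1 and changes only the ether: methyl in place of cyclobutyl on a saturated chain carbon bound to an oxygen on an aromatic ring. Three carbons are lost from a saturated, uncharged group with no donors or acceptors. For the measured compounds named here, the measured set offers no direct precedent for this change, so the expectation rests on the size of what leaves.

The step from compound 1 to compound 4 is estimated as a clear drop, a number 1.20 log units lower from compound 1 to compound 4 (beyond the scatter), well beyond the scatter. In this assay compound 4 is expected to give about 1.7, with a likely range from 1.2 to 2.2.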

Compound 4, distribution coefficient: 1.49
The estimate for compound 4 lay 0.21 log units above the measured number; the range from low to high includes it.
By their numbers in this assay, from the lowest: compound 4; then compound 2; then compound 3; then compound 1.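

Placing methyl in place of cyclobutyl, on a saturated chain carbon bound to an oxygen on an aromatic ring, gives the first clean single-place comparison in this assay and moves the read-out by a large amount: a number 1.41 log units lower from compound 1 to compound 4 (beyond the scatter) on an otherwise unchanged core. Among the compounds shown here, this shows that the read-out at this position responds strongly to the group carried there, which the earlier compounds could not show because they differ in more than one place. Nothing measured here accounts for the size of the step.

The compounds shown leave open whether the step follows the loss of the ring or the loss of carbons, a question that a cyclopropyl group, an open butyl chain or an amine at the same place could address. They also leave open whether a step of this size would hold on the cores of compound 2 and compound 3.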